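This account rests on a few compounds, and the source may have more. Where it says the series, first, only, none or still open, it means among the compounds named here.

Three compounds share one core and differ only in what hangs on the carbonyl carbon. Compound 1 `COc1cc(Cl)cc(-c2nn(-c3cccc(NC(=O)Nc4cccc(C(F)(F)F)c4)c3)cc2-c2ccncc2)c1` carries a urea, and in a functional assay on Malme-3M cells (Homo sapiens) for inhibition, read by sulforhodamine B assay, with a stated time of 48 h, tested at 10 uM (on this read-out higher numbers stand for a weaker effect at the one concentration tested and lower numbers for a stronger effect), compound 1 gives -16.6%. Compound 2 `COc1cc(Cl)cc(-c2nn(-c3cccc(NC(=O)Nc4ccc(Cl)c(C(F)(F)F)c4)c3)cc2-c2ccncc2)c1` has a chloro in place of hydrogen on an aromatic carbon, and compound 2 gives -19.8%; the step of a number 3.2 percentage points lower from compound 1 to compound 2 (within the scatter) lies within the scatter, so these two read alike. Compound 3 `COc1cc(Cl)cc(-c2nn(-c3cccc(NC(=O)c4cccc(C(F)(F)F)c4)c3)cc2-c2ccncc2)c1` has an amide in place of the urea, and compound 3 gives 92.4%, the highest of the three numbers, meaning the weakest effect at the one concentration tested. The steps of a number 109 percentage points higher from compound 1 to compound 3 (beyond the scatter) and a number 112.2 percentage points higher from compound 2 to compound 3 (beyond the scatter) are both large and beyond the scatter.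

Compound 4 `COc1cc(Cl)cc(-c2nn(-c3cccc(NC(=O)Nc4ccc(Cl)c(Cl)c4)c3)cc2-c2ccncc2)c1` is now set against compound 3. The change is (3,4-dichlorophenyl)amino in place of 3-(trifluoromethyl)phenyl on a carbonyl carbon. This restores the urea arrangement found in compounds 1 and 2, with a (3,4-dichlorophenyl)amino group where those two carried (3-(trifluoromethyl)phenyl)amino or (4-chloro-3-(trifluoromethyl)phenyl)amino. The two steps that bear on it, from compound 1 and from compound 2 to compound 3, were both large, and the reverse direction is expected here. The number for compound 4 in this assay is therefore expected to fall near those of compounds 1 and 2, a step of a number 110.4 percentage points lower from compound 3 to compound 4 (beyond the scatter). The estimate for compound 4 is -18%, with a range from -45% to 15%.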

Compound 4, a percentage reported as activity, at one concentration (the size of the read-out at that concentration, not a potency): -19.8%
Compound 4: the middle estimate sits 1.8 percentage points above what was measured, within the range that was stated.
By their numbers in this assay, from the lowest: compounds 2, 4 and 1 (each within the scatter of the next); then compound 3.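

Returning to a urea gives a number 112.2 percentage points lower from compound 3 to compound 4 (beyond the scatter) in this assay, so the large gap seen from compounds 1 and 2 to the amide compound 3 now appears with a third urea carrying a different aromatic ring. Within the ureas, chloro in place of trifluoromethyl gives no change at the digits printed from compound 2 to compound 4 (within the scatter), and 3,4-dichlorophenyl in place of 3-(trifluoromethyl)phenyl on the amide-type nitrogen gives a number 3.2 percentage points lower from compound 1 to compound 4 (within the scatter) in the same read-out, which means compound 4 keeps the strong effect with no trifluoromethyl group at all. Across these four compounds, the three ureas read alike and only compound 3, the amide, stands apart, so at this position the urea link matters far more than which of these halogen-bearing rings sits on it, although compound 3 also differs from compound 4 in its ring.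

Nothing given here explains why the urea and the amide read so differently. On these data alone, it also remains open whether the urea would keep this effect with a ring bearing a carboxylic acid or a dimethylamino group, or with a longer chain of methylene groups in place of the aromatic ring.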